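The compounds below may be only part of what the source reports. "The series", "measured", "known", "first", "only" and "open" are said of these compounds alone.

Working notes on the series. Compound 1 `COc1ccc(-c2cc(/C=C/C(=O)c3ccc(N)cc3)[nH]n2)cc1` and compound 2 `COc1cc(-c2cc(/C=C/C(=O)c3ccc(N)cc3)[nH]n2)cc(OC)c1OC` share one core and differ only in the methoxy pattern on the aryl ring attached to it. In a functional assay on NCI-H322M cells (Homo sapiens) for cytotoxicity, read by sulforhodamine B assay, with a stated time of 48 h, tested at 100 uM (a lower number here means a stronger effect, a higher number a weaker effect of the compound at the concentration tested), compound 1 gives -98%. In this assay, within the data shown here, compound 2 gives -89%, the upper of the two numbers measured so far; the gap to compound 1 lies within the usual scatter, so the two compounds are not separated by this read-out. Among the measured compounds shown here, no step between measured compounds that differ in a single place is available, so there is no measured step to lean on.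

Compound 3 `COc1ccc(-c2cc(/C=C/C(=O)c3ccc(N)cc3)[nH]n2)cc1OC` is the next member to be measured. Relative to compound 2 the change is hydrogen in place of methoxy on an aromatic carbon. Since compound 1 with -98% and compound 2 with -89% sit close together in this assay, the change is expected to move the number little. The step from compound 2 to compound 3 is expected to be a number 4 percentage points lower from compound 2 to compound 3 (within the scatter), none beyond the scatter. For compound 3 in this assay the estimate is -93%, with a range from -100% to -78%.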

Compound 3, a percentage reported as activity, at one concentration (the size of the read-out at that concentration, not a potency): -88%
Beside the measured number, compound 3's estimate is 5 percentage points below it, and the stated range covers the measured number.
By their numbers in this assay, from the lowest: compounds 1, 2 and 3 (each within the scatter of the next).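

With compound 3, the series has its first steps between compounds that differ in one place. In this assay, hydrogen in place of methoxy on an aromatic carbon, ortho to a methoxy group and meta to a large group, gives a number 1 percentage points higher from compound 2 to compound 3 (within the scatter) and so does not separate the two compounds at this position. Methoxy in place of hydrogen on an aromatic carbon gives a number 10 percentage points higher from compound 1 to compound 3 (within the scatter) and likewise separates nothing, so neither of these two single changes in the methoxy pattern has a step beyond the scatter in this read-out at one concentration. No supporting measurement bears on these steps.

From the compounds shown here alone, whether a hydroxy group, a chlorine atom or an ethoxy chain on the same aromatic carbon would also stay within the scatter remains open. Going by these compounds, the amine on the shared core is also constant across all three compounds, so the effect of a carboxylic acid or an acetamide in its place is unknown.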